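From (oxiran-2-yl)methoxy to 3-chloro-2-hydroxypropoxy on compound 1

The compounds below may be only part of what the source reports. "The series", "measured", "known", "first", "only" and "open" are said of these compounds alone.

Within the data shown here, in a functional assay on DU-145 cells (Homo sapiens) for cytotoxicity, read by MTT assay (on this read-out lower numbers stand for stronger inhibition and higher numbers for weaker inhibition), compound 1 (`COc1ccc(C(=O)/C=C/c2ccc(OCC3CO3)cc2)cc1`) gives 36900 nM as the only numerical reading so far. Compound 2 (`O=C(/C=C/c1ccc(OCC2CO2)cc1)c1ccc(OCC2CO2)cc1`) gives > 50000 nM there, which is a limit and not a number.

Compound 3 (`COc1ccc(C(=O)/C=C/c2ccc(OCC(O)CCl)cc2)cc1`) carries this change on compound 1: 2-chloro-1-hydroxyethyl in place of oxiran-2-yl on a saturated chain carbon bound to an oxygen on an aromatic ring (the same difference reads (oxiran-2-yl)methyl to 3-chloro-2-hydroxypropyl). Among the measured compounds shown here, the one measured step runs an at least 1.3-fold higher number from compound 1 to compound 2 (0.13 log units; that floor lies within the scatter) and concerns a different change, oxiran-2-yl in place of hydrogen, with the group that leaves here kept in place. For the measured compounds named here, no measured step replaces oxiran-2-yl itself, so the data give no direction for this change. The anchor is therefore compound 1 at 36900 nM and that value alone. The estimated change in this assay is a 1.2-fold lower number from compound 1 to compound 3 (0.09 log units; within the scatter) and no shift beyond the scatter is expected. For compound 3 the expected value is 30000 nM with 12000 nM to 60000 nM as the estimated range.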

Compound 3, half-maximal inhibitory concentration: > 50000 nM
Compound 3: a limit, no number (the forecaster's own chance of this, stated with the estimate: 25%); at least 1.6-fold (0.22 log units) between middle value and limit.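

In this assay compound 3 gives > 50000 nM, a limit and not a number. This is the first reading on a replacement of oxiran-2-yl itself, and the step is an at least 1.3-fold higher number from compound 1 to compound 3 (0.13 log units; that floor lies within the scatter), so 2-chloro-1-hydroxyethyl on a saturated chain carbon bound to an oxygen on an aromatic ring yields no numerical reading, and the only number in the series stays with compound 1, yet no loss beyond the scatter is shown. Only the floor of this step is known, and further changes at this position can be ordered only once they give numbers: the limit of > 50000 nM in this assay, at which 2 of the 3 values shown sit.

Still open, going by these compounds, is how far the true value of compound 3 lies past its limit, and so whether opening the three-membered ring changes the reading beyond the scatter at all. Also open, on these data alone, is what an amine in place of the chlorine of 2-chloro-1-hydroxyethyl, or a longer chain carrying oxiran-2-yl on the same oxygen, would give in this assay on the core of compound 1.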